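The compounds below may be only part of what the source reports. "The series", "measured", "known", "first", "only" and "open" are said of these compounds alone.

compound 1 `C/N=C(/S)C1=CC(C)(CF)Oc2ccc([N+](=O)[O-])cc21`: 1.62 nM
compound 2 `CNC(=O)C1=CC(C)(CF)Oc2ccc([N+](=O)[O-])cc21`: 8.91 nM
compound 3 `CC1(C)C=C(C(=O)NCCC#N)c2cc([N+](=O)[O-])ccc2O1`: 2.82 nM

In a functional assay (aorta) with Rattus norvegicus as the target (on this read-out lower numbers stand for an effect already at smaller amounts and higher numbers for an effect only at larger amounts of compound), compound 3 gives 2.82 nM. That lies within the usual scatter of compound 1 and is a clearly lower number than that of compound 2 . The next compound, compound 4 `CC1(CF)C=C(C(=O)NCCC#N)c2cc([N+](=O)[O-])ccc2O1`, differs from compound 3 in one place: fluoro in place of hydrogen on a saturated chain carbon bound to a saturated ring carbon. Put simply, this is fluoro in place of hydrogen on a saturated chain carbon bound to a saturated ring carbon, which turns methyl to fluoromethyl.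

For the measured compounds named here, no measured pair shows this change on its own. Going by the values given here, the only measured step, a 5.5-fold higher number from compound 1 to compound 2 (0.74 log units; beyond the scatter), is a swap of sulfur for oxygen elsewhere in the molecule, so it shows only how far a single change can move the number in this small set. Fluoromethyl is already present in compound 1 at 1.62 nM and in compound 2 at 8.91 nM, but both also differ from compound 3 in their other group. These values therefore give no firm direction, and no change beyond the scatter is expected in this assay. The estimate amounts to a 1.2-fold higher number from compound 3 to compound 4 (0.09 log units; within the scatter). For compound 4 the expected value is 3.5 nM, with an estimated range from 1.2 nM to 10 nM.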

Compound 4, half-maximal effective concentration: 3.98 nM
Compound 4: middle estimate off by 1.1-fold (0.06 log units), on the low side; the range from low to high includes it.
By their numbers in this assay, from the lowest: compounds 1, 3 and 4 (each within the scatter of the next, the first and the last beyond it); then compound 2.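

In this assay, for the compounds shown here, the methyl to fluoromethyl change can be read on its own for the first time, and a 1.4-fold higher number from compound 3 to compound 4 (0.15 log units; within the scatter) shows that, with this amide side chain in place, fluoro in place of hydrogen at this position leaves the number within the usual variation. Holding fluoromethyl fixed also makes the side chain readable: a 2.2-fold lower number from compound 2 to compound 4 (0.35 log units; beyond the scatter) comes with cyanomethyl in place of hydrogen on a saturated chain carbon bound to an amide-type nitrogen, so this change matters more here than the fluoro does. Going the other way, a 2.5-fold higher number from compound 1 to compound 4 (0.39 log units; beyond the scatter) comes with the amide side chain in place of the sulfur-bearing group, which leaves compound 1 with the lowest number of the three fluoromethyl compounds.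

No supporting measurement explains why any of these steps has its size. Still open, on these data alone, is whether difluoromethyl, trifluoromethyl or a longer chain such as ethyl at this position would also stay close to compound 3, and whether the methyl to fluoromethyl change would read the same alongside the sulfur-bearing group of compound 1.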